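A few compounds are considered here, and "the series" means these few. Any claim that something is new, unique, unknown or untested is made for them only; others in the source may bear on it.

Of the compounds shown here, three that share one core have been measured so far. Compound 1 `O=S(=O)(NCCCNCC1COc2ccccc2O1)c1cc(C(F)(F)F)cc(C(F)(F)F)c1` gives 2900 nM in a functional assay on ASPC1 cells (Homo sapiens) for inhibition, read by MTT assay, with a stated time of 72 h; on this read-out lower numbers stand for stronger inhibition of growth and higher numbers for weaker inhibition of growth. Compound 2 `O=S(=O)(NCCCNCc1cccc2ccccc12)c1cc(C(F)(F)F)cc(C(F)(F)F)c1` gives 21000 nM in this assay, and compound 3 `O=S(=O)(NCCCNCc1cccc(Cl)c1)c1cc(C(F)(F)F)cc(C(F)(F)F)c1` gives 5900 nM in this assay. Compound 3 thus stands second highest of the three numbers, nearest to compound 1 and furthest from compound 2. The steps among them are all modest: a 2.0-fold higher number from compound 1 to compound 3 (0.31 log units; beyond the scatter), a 7.2-fold higher number from compound 1 to compound 2 (0.86 log units; beyond the scatter) and a 3.6-fold lower number from compound 2 to compound 3 (0.55 log units; beyond the scatter). Compound 4 `COc1ccccc1CNCCCNS(=O)(=O)c1cc(C(F)(F)F)cc(C(F)(F)F)c1` differs from compound 3 in one place: 2-methoxyphenyl in place of 3-chlorophenyl on a saturated chain carbon bound to an amine nitrogen. Going by the values given here, no measured step exchanges one substituted phenyl for another, so the three steps only show the scale that a swap of the group on the saturated chain carbon bound to an amine nitrogen has produced. On that basis a step of similar modest size is expected in this assay, with no firm direction, and compound 4 is therefore estimated at 5000 nM, within 1800 nM to 14000 nM, which means an expected step of a 1.2-fold lower number from compound 3 to compound 4 (0.07 log units; within the scatter).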

Compound 4, concentration for 50% growth inhibition: 4600 nM
Estimate against measurement, compound 4: 1.1-fold (0.04 log units) above; the measured number falls inside the stated range.
By their numbers in this assay, from the lowest: compounds 1, 4 and 3 (each within the scatter of the next, the first and the last beyond it); then compound 2.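

In this assay, going by these compounds alone, the exchange of 3-chlorophenyl for 2-methoxyphenyl on a saturated chain carbon bound to an amine nitrogen gives a 1.3-fold lower number from compound 3 to compound 4 (0.11 log units; within the scatter), the first measured swap of one substituted phenyl for another, and it stays within the scatter although the entering group carries a hydrogen-bond acceptor that the leaving group lacks. The 2-methoxyphenyl group also stays within the scatter of the 2,3-dihydro-1,4-benzodioxin-2-yl group, with a 1.6-fold higher number from compound 1 to compound 4 (0.20 log units; within the scatter), whereas the change from naphthalen-1-yl gives a 4.6-fold lower number from compound 2 to compound 4 (0.66 log units; beyond the scatter), so among these compounds only the naphthalen-1-yl group stands clearly apart from 2-methoxyphenyl. No measurement at hand accounts for these steps.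

The compounds shown leave open how an amine or a carboxylic acid on the phenyl ring would read in this assay. They also leave open what a longer chain in the shared core would do.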